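Sulfonamide versus chloroalkyl on the triazole arm

This account rests on a few compounds, and the source may have more. Where it says the series, first, only, none or still open, it means among the compounds named here.

Compound 3 `O=C1O[C@H]([C@@H](O)Cn2cc(CCCCl)nn2)C(OCc2ccccc2)=C1OCc1ccccc1` gives 24500 nM in a functional assay on MCF7 cells (Homo sapiens) for antiproliferative activity, read by MTT assay, with a stated time of 72 h (on this read-out higher numbers stand for weaker inhibition and lower numbers for stronger inhibition), and stands at the highest, weakest end of the three measured compounds. Compound 1 `CCCCCCCCCCc1cn(C[C@H](O)[C@H]2OC(=O)C(OCc3ccccc3)=C2OCc2ccccc2)nn1` gives 80 nM in this assay, and compound 2 `O=C1O[C@H]([C@@H](O)Cn2cc(CNS(=O)(=O)c3ccc(Cl)cc3)nn2)C(OCc2ccccc2)=C1OCc1ccccc1` gives 4170 nM. The steps to compound 3 are a 310-fold higher number from compound 1 to compound 3 (2.49 log units; beyond the scatter) and a 5.9-fold higher number from compound 2 to compound 3 (0.77 log units; beyond the scatter), both beyond the scatter, so compound 3 is the least active of the three on this read-out.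

Compound 4 `O=C1O[C@H]([C@@H](O)Cn2cc(CNS(=O)(=O)c3ccc(Cl)cc3F)nn2)C(OCc2ccccc2)=C1OCc1ccccc1` is not yet measured. The change from compound 3 is ((4-chloro-2-fluorophenyl)sulfonyl)amino in place of 2-chloroethyl on a saturated chain carbon bound to an aromatic carbon. The measured step that bears on it is a 5.9-fold higher number from compound 2 to compound 3 (0.77 log units; beyond the scatter), since compound 4 carries the ((4-chloro-2-fluorophenyl)sulfonyl)amino group where compound 2 carries ((4-chlorophenyl)sulfonyl)amino. Going by the values given here, no measured pair in this set isolates the effect of the fluorine in that ring, so the expectation rests on reversing the modest step from compound 2 to compound 3, with a widened range. The step from compound 1 to compound 2 (a 52-fold higher number from compound 1 to compound 2 (1.72 log units; beyond the scatter)) shows that the sulfonamide arm remains well short of the nonyl chain, so a return toward the level of compound 1 is not expected.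

For compound 4 the expected step is a 6.4-fold lower number from compound 3 to compound 4 (0.81 log units; beyond the scatter), a modest lowering of the number. The estimate for compound 4 in this assay is 3800 nM, with a range from 1500 nM to 10000 nM.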

Compound 4, half-maximal inhibitory concentration: 3390 nM
Estimate against measurement, compound 4: 1.1-fold (0.05 log units) above; the range from low to high includes it.
By their numbers in this assay, from the lowest: compound 1; then compounds 4 and 2 (each within the scatter of the next); then compound 3.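

Fluoro in place of hydrogen on an aromatic carbon of the sulfonamide arm is the first single change made within that arm, and in this assay it gives a 1.2-fold lower number from compound 2 to compound 4 (0.09 log units; within the scatter), so compound 2 and compound 4 cannot be told apart on this read-out. The fluorinated sulfonamide arm still holds the same two relations as the unfluorinated one: a 7.2-fold lower number from compound 3 to compound 4 (0.86 log units; beyond the scatter) puts it clearly ahead of the chloroalkyl arm, while a 42-fold higher number from compound 1 to compound 4 (1.63 log units; beyond the scatter) leaves it well short of the nonyl chain. The data at hand give no measured reason for any of these steps.

Still open, as far as these compounds go, is how much of the standing of compound 1 depends on chain length, which a pentyl or a dodecyl chain on the saturated chain carbon bound to an aromatic carbon would test against the nonyl chain. Equally open, from the compounds shown here alone, is whether the sulfonamide arm tolerates larger changes to its ring than a single fluoro, such as a methoxy group or a carboxylic acid in place of the chloro, or an unsubstituted phenyl ring.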